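From acetamido to methanesulfonamido: working notes on the series

A few compounds are considered here, and "the series" means these few. Any claim that something is new, unique, unknown or untested is made for them only; others in the source may bear on it.

Compound 1 `Nc1ccc(-c2cn([C@@H]3CN[C@H](C(=O)Nc4ccc(Cl)c(C(F)(F)F)c4)C3)nn2)cn1`: 10400 nM
Compound 2 `CC(=O)Nc1ccc(-c2cn([C@@H]3CN[C@H](C(=O)Nc4ccc(Cl)c(C(F)(F)F)c4)C3)nn2)cn1`: 8980 nM

In a functional assay on K562 cells (Homo sapiens) for inhibition, read by MTT assay, with a stated time of 48 h (on this read-out lower numbers stand for stronger inhibition and higher numbers for weaker inhibition), compound 2 gives 8980 nM, within the scatter of compound 1 at 10400 nM. Compound 3 `CS(=O)(=O)Nc1ccc(-c2cn([C@@H]3CN[C@H](C(=O)Nc4ccc(Cl)c(C(F)(F)F)c4)C3)nn2)cn1` carries methylsulfonyl in place of acetyl on a nitrogen on an aromatic ring. Among the compounds with values here, the only measured step at this nitrogen, a 1.2-fold lower number from compound 1 to compound 2 (0.06 log units; within the scatter), lies within the scatter. That step is a single one and a different change, so it is weak guidance, and no shift beyond the scatter is expected in this assay. The expected step is a 1.1-fold lower number from compound 2 to compound 3 (0.02 log units; within the scatter). Compound 3 is estimated at 8500 nM, with an expected range of 4000 nM to 17000 nM.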

Compound 3, half-maximal inhibitory concentration: 5060 nM
Beside the measured number, compound 3's estimate is 1.7-fold (0.23 log units) above it, and the stated range covers the measured number.
By their numbers in this assay, from the lowest: compounds 3, 2 and 1 (each within the scatter of the next, the first and the last beyond it).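

In this assay, within the data shown here, methylsulfonyl in place of hydrogen on this nitrogen gives a 2.1-fold lower number from compound 1 to compound 3 (0.31 log units; beyond the scatter) and is the one step here beyond the scatter, though a modest one. Methylsulfonyl in place of acetyl gives a 1.8-fold lower number from compound 2 to compound 3 (0.25 log units; within the scatter) and stays within the scatter, so these two groups are not separated at this position. Nothing available bears on the reason for this result. Open, as far as these compounds go, is whether a longer chain on the sulfonyl, such as ethylsulfonyl, or a urea at this nitrogen would move the number further.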